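Hexyl to 3,5-Difluorophenyl on a Shared Core

The source may hold more compounds than are shown below. What is called first, only, known or untested is meant among the compounds shown, and "the series" means these compounds.

Compound 1 `CC(O)c1cn(Cc2cc(=O)oc3cc(O)ccc23)nn1` gives in a functional assay on SW-620 cells (Homo sapiens) for inhibition, read by MTT assay, with a stated time of 72 h (on this read-out higher numbers stand for weaker inhibition and lower numbers for stronger inhibition), only a limit of > 100000 nM.
Compound 2 `CCCCCCc1cn(Cc2cc(=O)oc3cc(O)ccc23)nn1` gives in this assay only a limit of > 100000 nM.

Compound 2 therefore stands at the limit of this assay, as does compound 1, which is the limit of > 100000 nM in this assay, at which 2 of the 2 values shown sit. Among the compounds with values here, the one measured step, a step that the two limits leave unreadable from compound 1 to compound 2, cannot be read as a size because both ends are limits. Compound 3 `O=c1cc(Cn2cc(-c3cc(F)cc(F)c3)nn2)c2ccc(O)cc2o1` differs from compound 2 by 3,5-difluorophenyl in place of hexyl on an aromatic carbon. Within the data shown here, no measured step bears on this change in a readable way, so there is no basis for expecting a rise or a fall beyond the scatter; the only guide is that both measured compounds sit at the limit. Compound 3 is therefore expected to come out near the limit of this assay as well, at an estimated 100000 nM within 30000 nM to 300000 nM. The step of a number no higher from compound 2 to compound 3 (the limit leaves the size open) is expected to be essentially flat.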

Compound 3, half-maximal inhibitory concentration: 66700 nM
For compound 3 the middle estimate is 1.5-fold (0.18 log units) above the measured one; the range from low to high includes it.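

Compound 3 is the only one of the three compounds with a readable number in this assay, while the other values rest at a limit: the limit of > 100000 nM in this assay, at which 2 of the 3 values shown sit.
Replacing the hexyl chain with 3,5-difluorophenyl gives an at least 1.4-fold lower number from compound 2 to compound 3 (0.17 log units; that floor lies within the scatter), and replacing 1-hydroxyethyl with the same ring gives an at least 1.4-fold lower number from compound 1 to compound 3 (0.17 log units; that floor lies within the scatter). Each is only a floor and does not establish a change beyond the scatter, so what is new is a single number at this position against which further changes can be sized.

The compounds shown leave open whether the ring alone or its two fluorines matter for this number, which a plain phenyl would help to separate. They also leave open how an amine or a carboxylic acid on this aromatic carbon would read in this assay.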